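Solubility of Two Nitroimidazole Sulfonamide Pairs

The source may hold more compounds than are shown below. What is called first, only, known or untested is meant among the compounds shown, and "the series" means these compounds.

Measured so far:
Compound 1 `COCCNS(=O)(=O)CCn1ccnc1[N+](=O)[O-]`: 59400000 nM
Compound 2 `O=[N+]([O-])c1nccn1CCS(=O)(=O)NCCO`: 75300000 nM
Compound 3 `COCCNS(=O)(=O)CCn1cncc1[N+](=O)[O-]`: 24400000 nM

All three numbers come from a physicochemical assay for solubility, read by HPLC; on this read-out lower numbers stand for lower solubility and higher numbers for higher solubility. Compound 1 and compound 2 share a core and differ only by hydrogen in place of methyl on an oxygen on a saturated carbon; that change gave a 1.3-fold higher number from compound 1 to compound 2 (0.10 log units; within the scatter). Compound 3 carries the same atoms as compound 1 joined differently; the difference between the two cores is not broken down here. In this assay compound 3 stands lowest of the three, with the nearest number that of compound 1.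

Compound 4 `O=[N+]([O-])c1cncn1CCS(=O)(=O)NCCO` is not yet measured. It relates to compound 3 exactly as compound 2 relates to compound 1: the change is hydrogen in place of methyl on an oxygen on a saturated carbon, the same change, at the same place. For the measured compounds named here, the only measured example of that change is the step from compound 1 to compound 2, which stayed within the scatter, so the expected step here is a 1.3-fold higher number from compound 3 to compound 4 (0.10 log units; within the scatter), a shift of about the same size. On that basis, compound 4 is estimated at 31000000 nM in this assay, with a likely range from 15000000 nM to 65000000 nM.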

Compound 4, solubility: 69300000 nM
The estimate for compound 4 lay 2.2-fold (0.35 log units) below the measured number, outside the stated range (above it).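

In this assay, hydrogen in place of methyl on an oxygen on a saturated carbon gave a 2.8-fold higher number from compound 3 to compound 4 (0.45 log units; beyond the scatter) on one core, while the same change gave a 1.3-fold higher number from compound 1 to compound 2 (0.10 log units; within the scatter) on the other. This shows that the size of a step measured on one core did not carry over to the other core in this series, even though the methoxy to hydroxy change was the same and stood at the same place. For the compounds shown here, it does not show a general rule, since it rests on only two pairs of compounds, and nothing available here explains why the two cores differ.

The compounds shown leave open how other groups in place of the 2-hydroxyethyl would behave on these two cores, such as an amine, a carboxylic acid or a longer chain ending in a hydroxy group. They also leave open whether the step seen from one core to the other would hold for such groups, or for a third core.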